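Working notes on an anilide series: compound 2 to compound 4

The source may report more compounds than this note shows. Statements on the series, on what has been measured and on what is new or still open speak of the compounds shown alone.

Measured so far in a functional assay on MDA-MB-231 cells (Homo sapiens) for antiproliferative activity, read by MTT assay, with a stated time of 72 h; a higher number here means a weaker inhibitor, a lower number a stronger inhibitor:
compound 1 `CC(C)(C)OC(=O)NCc1ccc(NC(=O)CCc2cccc3c2B(O)OC3)cc1`: 1300 nM
compound 2 `CC(C)c1cccc(NC(=O)CCc2cccc3c2B(O)OC3)c1`: 1600 nM
compound 3 `O=C(CCc1cccc2c1B(O)OC2)Nc1cccc2ccccc12`: 150 nM

Compound 2 gives the highest number of the three in this assay. Its nearest neighbour is compound 1, whose value lies within the scatter of that of compound 2, so no order between these two is claimed. Compound 3 gives a number far lower than that of compound 2, beyond the scatter; the two values show that the larger aromatic group on the amide nitrogen of compound 3 goes with a much lower number in this assay.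

Compound 4 `CSc1cccc(-c2cccc(NC(=O)CCc3cccc4c3B(O)OC4)c2)c1` is not yet measured. It differs from compound 2 in one place: 3-(methylsulfanyl)phenyl in place of isopropyl on an aromatic carbon. With this change compound 4, like compound 3, carries a second aromatic ring on the amide side of the shared core, though in a different arrangement. For the measured compounds named here, the pair compound 2 and compound 3, where compound 3 gives 150 nM, is the only guide for the size of such a step.

A downward step from compound 2 to compound 4 of a 4.0-fold lower number from compound 2 to compound 4 (0.60 log units; beyond the scatter) is expected, beyond the scatter. Compound 4 is estimated at 400 nM, with a range from 120 nM to 1300 nM.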

Compound 4, half-maximal inhibitory concentration: 150 nM
For compound 4 the middle estimate is 2.7-fold (0.43 log units) above the measured one, within the range that was stated.
By their numbers in this assay, from the lowest: compounds 3 and 4 (each within the scatter of the next); then compounds 1 and 2 (each within the scatter of the next).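

In this assay, for the compounds shown here, the exchange of isopropyl for 3-(methylsulfanyl)phenyl on this aromatic carbon, meta to a large group, gives an 11-fold lower number from compound 2 to compound 4 (1.03 log units; beyond the scatter) and is the first step that can be read at a single place. Going by these compounds alone, it shows that this position accepts a group with a whole further aromatic ring and that the larger group goes with a much lower number, which the earlier compounds, differing in more than one place, could not show. Nothing at hand accounts for the size of this step.

Still open, from the compounds shown here alone, is whether the step belongs to the added ring or to the methylsulfanyl group on it, which a plain phenyl at this carbon would separate. Also open, going by these compounds, is how an amine, a carboxylic acid or a longer alkyl chain would read at this position.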